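The compounds below may be only part of what the source reports. "The series", "measured", "known", "first", "only" and "open" are said of these compounds alone.

Working notes on the series. The shared core is carried by compound 1 `CC1(C)O[C@H]2[C@H](OCc3noc(-c4ccc([N+](=O)[O-])cc4)n3)O[C@H](CSc3ncn[nH]3)[C@H]2O1` and compound 2 `O=[N+]([O-])c1ccc(-c2nc(CO[C@@H]3O[C@H](CSc4ncn[nH]4)[C@H]4OC5(CCCC5)O[C@@H]34)no2)cc1`. In a functional assay on WiDr cells (Homo sapiens) for antiproliferative activity, read by sulforhodamine B assay, with a stated time of 48 h (on this read-out higher numbers stand for weaker inhibition of growth and lower numbers for stronger inhibition of growth), compound 1 gives only a limit, > 100000 nM, and no number. In this assay compound 2 gives 20000 nM. Among the measured compounds shown here, compound 1 thus stands at the limit of > 100000 nM in this assay, at which 1 of the 2 values shown sits, so no measured step leads out of it, and the pair with compound 2 shows only that one compound gives a number while the other gives a limit.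

The unmeasured compound 3 `CC1(C)O[C@H]2[C@H](OCc3noc(-c4ccc([N+](=O)[O-])cc4)n3)O[C@H](CSc3nnc(N)s3)[C@H]2O1` differs from compound 1 in one place: 5-amino-1,3,4-thiadiazol-2-yl in place of 1H-1,2,4-triazol-5-yl on a sulfur. For the measured compounds named here, no measured pair here shows this change, so its effect in this assay is unknown. With compound 1 giving > 100000 nM, the expected step from the limit is small, within the scatter or at most modest, and the estimate is an at least 1.1-fold lower number from compound 1 to compound 3 (0.04 log units; that floor lies within the scatter). For compound 3 the estimated value in this assay is 90000 nM, with a range from 30000 nM to 300000 nM, and a limit is again expected to be the likely outcome.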

Compound 3, concentration for 50% growth inhibition: > 100000 nM
Compound 3 gave a limit, no number; the forecaster's own chance of this, stated with the estimate: 60%; middle value at least 1.1-fold (0.04 log units) from the limit.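

Compound 1 and compound 3 both give only a limit in this assay, so no step between them can be read: the limit of > 100000 nM in this assay, at which 2 of the 3 values shown sit.

The compounds shown leave open what 5-amino-1,3,4-thiadiazol-2-yl in place of 1H-1,2,4-triazol-5-yl on a sulfur does to growth inhibition in this assay.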